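Cytotoxicity in MT2 cells: extending the nitrogen substituent

A few compounds are considered here, and "the series" means these few. Any claim that something is new, unique, unknown or untested is made for them only; others in the source may bear on it.

Measured so far in an ADME assay on MT2 cells (Homo sapiens) for cytotoxicity, read by XTT assay, with a stated time of 4 days; on this read-out higher numbers stand for lower toxicity in this test and lower numbers for higher toxicity in this test:
compound 1 `Cc1ccc(-c2c3c(nc(C)c2[C@H](OC(C)(C)C)C(=O)O)CCN(c2ccccc2)C3)cc1` gives > 40000 nM
compound 2 `CCCCCN1CCc2nc(C)c(C(OC(C)(C)C)C(=O)O)c(-c3ccc(C)cc3)c2C1` gives > 40000 nM

Both values are limits of this assay, not numbers. The value of compound 1 is a limit. The value of compound 2 is a limit as well. For the measured compounds named here, compound 1 therefore stands at the ceiling of what this assay reports, and the single further value shown sits at the same ceiling: the limit of > 40000 nM in this assay, at which 2 of the 2 values shown sit. No step between two measured compounds is available, so nothing in the shown data tells how large a change on the nitrogen substituent moves the read-out.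

Compound 3 `Cc1ccc(-c2c3c(nc(C)c2[C@H](OC(C)(C)C)C(=O)O)CCN(c2ccc(-c4ccccc4)cc2)C3)cc1` is not yet measured. It differs from compound 1 by phenyl in place of hydrogen on an aromatic carbon. Since both measured compounds sit at the limit, the expectation for compound 3 is that the step of a number no higher from compound 1 to compound 3 (the limit leaves the size open) is none beyond the scatter, with the read-out again most likely reported as a limit. Compound 3 is estimated at 40000 nM, in the range 12000 nM to 100000 nM.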

Compound 3, half-maximal cytotoxic concentration: > 40000 nM
Compound 3 was reported as a limit; the forecaster's own chance of this, stated with the estimate: 60%; the middle value sits exactly at the limit.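

In this assay, compound 3 also gives a limit, so no step can be read between compound 1 and compound 3, and the phenyl in place of hydrogen has no readable size: the limit of > 40000 nM in this assay, at which 3 of the 3 values shown sit.

The compounds shown leave open whether any change on the nitrogen substituent brings the half-maximal cytotoxic concentration to a measurable number.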